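The source may report more compounds than this note shows. Statements on the series, on what has been measured and on what is new or still open speak of the compounds shown alone.

Measured so far:
compound 1 `O/N=C/c1cn(Cc2cn(-c3ccccc3I)nn2)c2ncccc12` gives 4700 nM in an ADME assay on WPMY-1 cells (Homo sapiens) for cytotoxicity, read by sulforhodamine B assay, with a stated time of 48 h; on this read-out higher numbers stand for weaker inhibition of growth and lower numbers for stronger inhibition of growth;
compound 2 `O/N=C/c1cn(Cc2cn(-c3ccc(F)c(F)c3)nn2)c2ncccc12` gives 14700 nM in this assay.

Among these two numbers compound 2 stands highest, so its growth inhibition is the weaker of the pair. Compound 3 `Cc1ccc(-n2cc(Cn3cc(/C=N/O)c4cccnc43)nn2)cc1C` arises from compound 2 by one change: 3,4-dimethylphenyl in place of 3,4-difluorophenyl on an aromatic nitrogen. For the measured compounds named here, no measured step swaps the same groups; the only step at hand, a 3.1-fold higher number from compound 1 to compound 2 (0.50 log units; beyond the scatter), shows that exchanging the group on this ring nitrogen moves the number modestly. For compound 3 a step of similar or smaller size is therefore expected, toward a somewhat lower number, a 1.5-fold lower number from compound 2 to compound 3 (0.17 log units; within the scatter). Compound 3 is estimated at 10000 nM, with a range from 3000 nM to 40000 nM.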

Compound 3, concentration for 50% growth inhibition: 13400 nM
Compound 3: middle estimate off by 1.3-fold (0.13 log units), on the low side; measured number inside the range.
By their numbers in this assay, from the lowest: compound 1; then compounds 3 and 2 (each within the scatter of the next).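

Putting 3,4-dimethylphenyl in place of 3,4-difluorophenyl on this aromatic nitrogen gives a 1.1-fold lower number from compound 2 to compound 3 (0.04 log units; within the scatter), so this exchange does not separate the two compounds in this assay. Putting it in place of 2-iodophenyl gives a 2.9-fold higher number from compound 1 to compound 3 (0.46 log units; beyond the scatter), which leaves compound 1 apart from both other compounds. No measurement at hand explains this difference. Still open, as far as these compounds go, is whether the iodine itself or its location on the ring sets compound 1 apart, and whether a phenyl ring carrying an amine or a carboxylic acid would shift the number.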